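A Methyl Swap at the Edge of Measurement

The source may hold more compounds than are shown below. What is called first, only, known or untested is meant among the compounds shown, and "the series" means these compounds.

In a functional assay on MCF7 cells (Homo sapiens) for cytotoxicity, read by MTT assay, with a stated time of 48 h (a higher number here means a weaker inhibitor, a lower number a stronger inhibitor), compound 3 `Nc1ccc(Nc2nc(-c3cccc(F)c3)nc3ccc(F)cc23)cc1` gives > 50000 nM as a limit and not a number. Compound 2 `Fc1cccc(-c2nc(Nc3cccc(Cl)c3)c3cc(F)ccc3n2)c1` also gives > 50000 nM as a limit. Compound 1 `Fc1cccc(-c2nc(Nc3ccccc3)c3cc(F)ccc3n2)c1` gives a true number of 49700 nM in the same test. Compound 4 `Cc1cccc(Nc2nc(-c3cccc(F)c3)nc3ccc(F)cc23)c1` has 3-methylphenyl in place of 4-aminophenyl on a nitrogen on an aromatic ring. Among the compounds with values here, two measured steps bear on this, (a number no lower from compound 1 to compound 2 (the limit leaves the size open)) and (a number no lower from compound 1 to compound 3 (the limit leaves the size open)), and neither has a readable size. Given the limit of > 50000 nM in this assay, at which 2 of the 3 values shown sit, and these open steps, no change beyond the scatter is expected in this assay in either direction. The expected move is a number no higher from compound 3 to compound 4 (the limit leaves the size open) and it should stay small. Compound 4 is estimated at 50000 nM (range 20000 nM to 100000 nM) and may also read as a limit.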

Compound 4, half-maximal inhibitory concentration: > 50000 nM
Compound 4: no number, only a limit; the forecaster's own chance of this, stated with the estimate: 60%; the middle value sits exactly at the limit.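

In this assay compound 4 gives > 50000 nM, a limit and not a number. Within the data shown here, the one step with a direction is a number no lower from compound 1 to compound 4 (the limit leaves the size open), so 3-methylphenyl, with no hydrogen-bond donors or acceptors, ends at the same limit as 4-aminophenyl. The steps from compound 2 and from compound 3 to compound 4 cannot be read, because their values all stop at one mark: the limit of > 50000 nM in this assay, at which 3 of the 4 values shown sit.

How far past the limit each of these compounds lies stays open. So does whether another group at this place, such as a carboxylic acid or a longer chain, would give a readable number.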